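Anilide substituent removal in the dihydrofuran carboxamide series

The compounds below may be only part of what the source reports. "The series", "measured", "known", "first", "only" and "open" are said of these compounds alone.

compound 1: `C=CC1=C(C(=O)Nc2ccccc2)C(c2ccc(Cl)c(Cl)c2)OC1` — > 100000 nM
compound 2: `C=CC1=C(C(=O)Nc2ccccc2OC)C(c2ccc(F)cc2)OC1` — 52800 nM
compound 3: `C=CC1=C(C(=O)Nc2ccc(OCC)cc2)C(c2ccc(F)cc2)OC1` — 61600 nM

Of the compounds shown here, three have been measured in a functional assay on QGY7701 cells (Homo sapiens) for cytotoxicity, read by MTT assay, with a stated time of 24 h; a lower number here means a stronger inhibitor, a higher number a weaker inhibitor. For compound 1 the reading is a limit of the assay rather than a number, > 100000 nM (the limit of > 100000 nM in this assay, at which 1 of the 3 values shown sits). Compound 2 gives 52800 nM in this assay, and compound 3 gives 61600 nM. Of the two numbers, compound 3 holds the higher one, but its separation from compound 2 lies within the usual scatter, so no order between the two can be read.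

Compound 4, `C=CC1=C(C(=O)Nc2ccccc2)C(c2ccc(F)cc2)OC1`, has not yet been measured. Against compound 3 it differs by hydrogen in place of ethoxy on an aromatic carbon. Among the measured compounds shown here, no measured pair isolates this change: compound 1 also lacks a group at this place, but it differs elsewhere as well, so its limit says nothing clean about the substituent alone. For the measured compounds named here, with no measured step to rest on, the expected step from compound 3 to compound 4 is small, a 1.2-fold higher number from compound 3 to compound 4 (0.09 log units; within the scatter), with the weaker side slightly favoured. Compound 4 is accordingly estimated at 75000 nM, between 30000 nM and 160000 nM, with a real chance that only a limit is returned.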

Compound 4, half-maximal inhibitory concentration: 46700 nM
Beside the measured number, compound 4's estimate is 1.6-fold (0.21 log units) above it, within the range that was stated.
By their numbers in this assay, from the lowest: compounds 4, 2 and 3 (each within the scatter of the next). At a limit, above all of these: compound 1.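

In this assay, the anilide ring without a substituent cannot be told apart from its alkoxy-bearing counterparts: a 1.3-fold lower number from compound 3 to compound 4 (0.12 log units; within the scatter) for the loss of ethoxy, and a 1.1-fold lower number from compound 2 to compound 4 (0.05 log units; within the scatter) for the loss of methoxy. The first separation beyond the scatter comes from the other aryl group, with 4-fluorophenyl in place of 3,4-dichlorophenyl on a saturated ring carbon: an at least 2.1-fold lower number from compound 1 to compound 4 (0.33 log units; beyond the scatter). The reading for compound 1 in that step is a limit of the assay: the limit of > 100000 nM in this assay, at which 1 of the 4 values shown sits.

The compounds shown leave open whether an amine, a carboxylic acid or a chain longer than ethoxy on the anilide ring would stand apart from hydrogen. Also open, from the compounds shown here alone, is how a single chlorine on the other phenyl ring would read.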